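The compounds below may be only part of what the source reports. "The series", "measured", "known", "first", "only" and "open" are said of these compounds alone.

The two measured compounds share one core and differ at both aryl groups. In a functional assay on NCI-H460 cells (Homo sapiens) for inhibition, read by CCK-8 assay, with a stated time of 48 h (on this read-out lower numbers stand for stronger inhibition and higher numbers for weaker inhibition), compound 1 `Cc1ccc(NC(=S)NC(=O)c2cn(-c3ccccc3)nc2-c2ccc(F)cc2)cc1` gives 2980 nM. In this assay compound 2 `O=C(NC(=S)Nc1ccc(Cl)cc1)c1cn(-c2ccccc2)nc1-c1ccc(Cl)cc1` gives 3260 nM, the higher of the two numbers, though the gap to compound 1 is within the usual scatter, so neither can be called the stronger of the pair.

Compound 3 `O=C(NC(=S)Nc1ccc(Cl)cc1)c1cn(-c2ccccc2)nc1-c1ccc(F)cc1` follows from compound 2 by a single change: fluoro in place of chloro on an aromatic carbon. No measured pair isolates this change, so the step from compound 2 to compound 3 has no direct precedent in the numbers shown. Given that both measured compounds sit close together in this assay, compound 3 is expected to show no step beyond the scatter, which is what the estimated step of a 1.1-fold lower number from compound 2 to compound 3 (0.02 log units; within the scatter) means. Compound 3 is therefore estimated to give 3100 nM, with a range from 1500 nM to 6500 nM.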

Compound 3, half-maximal inhibitory concentration: 3090 nM
The estimate for compound 3 lay 1.0-fold (0.00 log units) above the measured number; the measured number falls inside the stated range.
By their numbers in this assay, from the lowest: compounds 1, 3 and 2 (each within the scatter of the next).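

In this assay, the exchange of 4-chlorophenyl for 4-fluorophenyl, on a carbon para to a large group, reads as a 1.1-fold lower number from compound 2 to compound 3 (0.02 log units; within the scatter), giving the first view of this position with nothing else altered, and here the two halogens cannot be told apart. On the other aryl group, chloro in place of methyl reads as a 1.0-fold higher number from compound 1 to compound 3 (0.02 log units; within the scatter), so the two aryl groups, which differed together between compound 1 and compound 2, can now each be read alone, and neither single change moves the number beyond the scatter. Nothing further is available to explain these results.

On these data alone, whether an amine, a carboxylic acid or a longer chain at either place would move the number beyond the scatter stays open. So does the outcome of placing a methoxy group on either aryl group.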